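This account rests on a few compounds, and the source may have more. Where it says the series, first, only, none or still open, it means among the compounds named here.

Compound 1 `COc1ccc(/C=C\C(=O)O)c(OCc2cn(-c3ccccc3C(=O)N3CCC(O)C3)nn2)c1CC=C(C)C` carries a (3-hydroxypyrrolidin-1-yl)carbonyl group on an aromatic carbon of its core. In a functional assay on COLO 205 cells (Homo sapiens) for cytotoxicity, read by MTT assay, with a stated time of 24 h (on this read-out higher numbers stand for weaker inhibition and lower numbers for stronger inhibition), compound 1 gives 25400 nM, the highest of the two numbers recorded here. Among the compounds with values here, compound 3 `COc1ccccc1-n1cc(COc2c(/C=C\C(=O)O)ccc(OC)c2CC=C(C)C)nn1` gives 12200 nM in this assay, and the single measured step, a 2.1-fold lower number from compound 1 to compound 3 (0.32 log units; beyond the scatter), comes from methoxy in place of (3-hydroxypyrrolidin-1-yl)carbonyl on an aromatic carbon. Compound 2 `COc1ccc(/C=C\C(=O)O)c(OCc2cn(-c3ccccc3I)nn2)c1CC=C(C)C` has no result in this assay; its entry reads "not determined" (no result reported).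

Compound 4 `COc1ccc(/C=C\C(=O)O)c(OCc2cn(-c3ccccc3C#N)nn2)c1CC=C(C)C` differs from compound 1 in one place: cyano in place of (3-hydroxypyrrolidin-1-yl)carbonyl on an aromatic carbon. Within the data shown here, the only step that bears on this change is a 2.1-fold lower number from compound 1 to compound 3 (0.32 log units; beyond the scatter), in which another group took the place of the same (3-hydroxypyrrolidin-1-yl)carbonyl, and that step was modest. On that basis a modest lowering of the number, of roughly the same size, is expected for compound 4, although the data give no direct comparison of cyano with methoxy. Compound 4 is therefore expected to give 14000 nM in this assay, within a range from 6000 nM to 35000 nM. This estimate corresponds to an expected step of a 1.8-fold lower number from compound 1 to compound 4 (0.26 log units; within the scatter).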

Compound 4, half-maximal inhibitory concentration: 3200 nM
Estimate against measurement, compound 4: 4.4-fold (0.64 log units) above, and the stated range ends above it.
By their numbers in this assay, from the lowest: compound 4; then compound 3; then compound 1.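

In this assay, within the data shown here, the group on this aromatic carbon turns out to have more room to shift the number than the one earlier step suggested, with cyano in place of (3-hydroxypyrrolidin-1-yl)carbonyl giving a 7.9-fold lower number from compound 1 to compound 4 (0.90 log units; beyond the scatter). Replacing the amide group does not have one fixed outcome, since the two replacements differ from each other beyond the scatter, with cyano in place of methoxy giving a 3.8-fold lower number from compound 3 to compound 4 (0.58 log units; beyond the scatter). Nothing available here accounts for the difference between cyano and the other two groups.

The compounds shown leave open whether an amine or a trifluoromethyl group at this place would give a number near that of compound 4 or nearer that of compound 3. Compound 2 has no result, so the iodo group offers no comparison at this place.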